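Lengthening the Aryl Chain in a Leukotriene Receptor Ligand

The compounds below may be only part of what the source reports. "The series", "measured", "known", "first", "only" and "open" are said of these compounds alone.

Compound 1, `O=C(O)CCC[C@H](O)[C@@H](/C=C\CCc1ccccc1)Sc1ccc(C(=O)O)cc1`: in an assay on membranes from lung for binding affinity to cysteinyl leukotriene receptor 1 (Cavia porcellus) (on this read-out lower numbers stand for stronger inhibition and higher numbers for weaker inhibition), compound 1 gives < 100000 nM; < 100000 nM (2 entries), which is a limit of the assay and not a number.
Compound 2, `O=C(O)CCC[C@H](O)[C@@H](/C=C/CCc1ccccc1)Sc1ccc(C(=O)O)cc1`: in this assay compound 2 gives < 100000 nM, again only a limit.

On the numbers shown, compound 2 has no definite place: its entry is a limit, and a further entry also gives no single number. Within the data shown here, the two measured compounds share (the fact that compounds 1 and 2 differ only in the configuration as drawn), and since both show only limits there is no measured step between them. Compound 3, `O=C(O)CCC[C@H](O)[C@@H](/C=C/CCCc1ccccc1)Sc1ccc(C(=O)O)cc1`, differs from compound 2 by benzyl in place of phenyl on a saturated chain carbon, two bonds along the chain from a double-bonded chain carbon. Without any measured step, the direction and size of this change in this assay cannot be read from the data. The step from compound 2 to compound 3 is expected to be a step that the limit leaves unreadable from compound 2 to compound 3, a rough guess only. Compound 3 is expected to give 10000 nM, within a range from 500 nM to 100000 nM, with a fair chance that again only a limit is reported.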

Compound 3, inhibition constant: < 100000 nM
Compound 3: only a limit was reported; the forecaster's own chance of this, stated with the estimate: 50%; the middle value lies beyond the limit too.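

Compound 2 and compound 3 both give only limits in this assay, not numbers, so no step between them can be read: the limit of < 100000 nM in this assay, at which 2 of the 3 values shown sit.

The compounds shown leave open whether benzyl in place of phenyl changes the inhibition at all, and how strong the inhibition by each compound actually is.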